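One Stereocentre Changed in a Weakly Cytotoxic Set

The source may report more compounds than this note shows. Statements on the series, on what has been measured and on what is new or still open speak of the compounds shown alone.

In a functional assay on K562 cells (Homo sapiens) for cytotoxicity, read by MTT assay, with a stated time of 48 h (on this read-out higher numbers stand for weaker inhibition and lower numbers for stronger inhibition), compound 3 (`CCOC(=O)[C@]1(C(=O)Nc2ccccc2Cl)C[C@H]1c1cc(OC)c(OC)c(OC)c1`) gives 20700 nM, the lower of the two single numbers available. Its mirror image, compound 2 (`CCOC(=O)[C@@]1(C(=O)Nc2ccccc2Cl)C[C@@H]1c1cc(OC)c(OC)c(OC)c1`), gives 49400 nM. Compound 1 (`CCOC(=O)C1(C(=O)Nc2ccccc2Cl)CC1c1cc(OC)c(OC)c(OC)c1`) is drawn without a defined configuration and gives 41400 nM; 14200 nM (2 entries), so its repeat entries do not settle on a single number.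

Compound 4 (`CCOC(=O)[C@@]1(C(=O)Nc2ccccc2Cl)C[C@H]1c1cc(OC)c(OC)c(OC)c1`) keeps the same atoms and bonds as compound 3: the two compounds have the same atoms and bonds and differ only in configuration as drawn: 1 of 2 stereo elements differ; a stereocentre at a saturated ring carbon is drawn R in compound 3 and S in compound 4. Among the compounds with values here, only one measured step bears on this change, and it comes from inverting all the stereocentres: a 2.4-fold lower number from compound 2 to compound 3 (0.38 log units; beyond the scatter). That step is modest, and the single inversion here is a different kind of change, so neither its size nor its direction carries over directly. A step of similar size or smaller is therefore expected, and no large jump in this assay. The step estimated here is a 1.4-fold higher number from compound 3 to compound 4 (0.13 log units; within the scatter). For compound 4 the expected value is 28000 nM, with an estimated range from 11000 nM to 70000 nM.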

Compound 4, half-maximal inhibitory concentration: > 100000 nM
Compound 4: a limit, no number (the forecaster's own chance of this, stated with the estimate: 10%); middle value at least 3.5-fold (0.55 log units) from the limit.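

Compound 4 gives no number in this assay: > 100000 nM is a limit of the assay. Changing a single stereocentre at a saturated ring carbon, drawn R in compound 3 and S in compound 4, gives an at least 4.8-fold higher number from compound 3 to compound 4 (0.68 log units; beyond the scatter), and since the atoms and bonds stay the same, this shift comes from configuration alone: the fact that compounds 3 and 4 differ only in the configuration as drawn Inverting both stereocentres had given only a 2.4-fold lower number from compound 2 to compound 3 (0.38 log units; beyond the scatter), so at this position one inversion can matter at least as much as inverting both, although an at least 2.0-fold higher number from compound 2 to compound 4 (0.30 log units; that floor lies within the scatter) has a floor that stays within the usual scatter.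

The compounds shown leave open whether this sensitivity to configuration is tied to the ethyl ester. Going by these compounds, all four carry that group, so the effect of a carboxylic acid or a primary amide in its place on the same stereocentre remains unknown.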